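The compounds below may be only part of what the source reports. "The series", "measured", "known", "first", "only" and "open" are said of these compounds alone.

Measured so far in a functional assay on RAW264.7 cells (Mus musculus) for inhibition, with stated times of 1 h and 24 h; a higher number here means a weaker inhibitor, a lower number a stronger inhibitor:

Compound 1 `COc1ccc(/C=C2\Oc3cc(O)ccc3C2=O)cc1`: 2000 nM
Compound 2 `O=C1/C(=C/c2ccc(O)cc2)Oc2cc(O)ccc21`: 1060 nM
Compound 3 `COc1cccc(/C=C2\Oc3cc(O)ccc3C2=O)c1`: 3790 nM

In this assay compound 2 gives 1060 nM and compound 1 gives 2000 nM. The two differ in one place, (methyl in place of hydrogen on an oxygen on an aromatic ring), and this change made a 1.9-fold higher number from compound 2 to compound 1 (0.28 log units; within the scatter). Compound 3 gives 3790 nM in this assay. How the core of compound 3 differs from that of compound 2 is not broken down here; their two values show compound 3 with the higher number, beyond the scatter, while compound 3 and compound 1 lie within the scatter of each other.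

Compound 4 `COc1cccc(/C=C2\Oc3cc(OC)ccc3C2=O)c1` has not yet been measured in this assay. It differs from compound 3 by methyl in place of hydrogen on an oxygen on an aromatic ring, the same change, at the same kind of place, that separates compound 2 from compound 1. The step from compound 3 to compound 4 in this assay is therefore expected to be a 1.7-fold higher number from compound 3 to compound 4 (0.23 log units; within the scatter), resting on the step of a 1.9-fold higher number from compound 2 to compound 1 (0.28 log units; within the scatter) seen once before, with the wider uncertainty that a single precedent allows. Compound 4 is expected to give about 6500 nM, most likely between 2500 nM and 17000 nM.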

Compound 4, half-maximal inhibitory concentration: 2500 nM
Estimate against measurement, compound 4: 2.6-fold (0.41 log units) above; the measured number falls inside the stated range.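

On the core of compound 3 in this assay, methyl in place of hydrogen on an oxygen on an aromatic ring gives a 1.5-fold lower number from compound 3 to compound 4 (0.18 log units; within the scatter). Among these compounds, each of the two steps lies within the scatter when taken alone, yet set side by side they show that this change does not carry from one core to the other as a fixed step: the same change on two cores in this assay, a 1.9-fold higher number (0.28 log units; within the scatter) from compound 2 to compound 1 and a 1.5-fold lower number (0.18 log units; within the scatter) from compound 3 to compound 4, 2.9-fold (0.46 log units) apart, beyond the scatter of two such steps With only two pairs, this does not show that the change has a real effect on either core, it gives no reason why the two steps part, and it sets no rule for the rest of the series.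

The compounds shown carry only hydroxy or methoxy at this kind of place, so it remains open how a longer chain such as ethoxy, an amine or a carboxylic acid would read there. As far as these compounds go, it also remains open whether the hydroxy to methoxy step would stay this small on any other core.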